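The source may report more compounds than this note shows. Statements on the series, on what has been measured and on what is new or still open speak of the compounds shown alone.

Of the compounds shown here, three sharing one core have been measured in an ADME assay on HepG2 cells (Homo sapiens) for cytotoxicity, with a stated time of 72 h; a higher number here means that more compound is needed for the effect, a lower number that less compound is needed. Compound 1 `Cc1cc(NC(=O)Nc2ccc(C(C)(C)C)cc2)c2ccccc2n1`, which carries tert-butyl, gives 17000 nM. Compound 2 `COC(=O)c1ccc(NC(=O)Nc2cc(C)nc3ccccc23)cc1`, with methoxycarbonyl at that place, gives 20000 nM. Compound 3 `Cc1cc(NC(=O)Nc2ccc(OC(F)(F)F)cc2)c2ccccc2n1`, with trifluoromethoxy there, gives 15000 nM. Compound 3 thus stands level with the other two, as the steps show: a 1.1-fold lower number from compound 1 to compound 3 (0.05 log units; within the scatter), and a 1.3-fold lower number from compound 2 to compound 3 (0.12 log units; within the scatter).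

The structural change now in question leads to compound 4 `Cc1cc(NC(=O)Nc2ccc(Cl)cc2)c2ccccc2n1`, which has chloro in place of trifluoromethoxy on an aromatic carbon, para to a large group: chloro in place of trifluoromethoxy on an aromatic carbon. The swap falls at the same place as all three measured steps, so each of them bears on it. Besides the two above, the third is a 1.2-fold higher number from compound 1 to compound 2 (0.07 log units; within the scatter). Three different groups at this place have therefore given numbers that cannot be told apart in this assay. Chloro itself has not yet been tested on this core, so this remains an extrapolation from a small set.

On that evidence, no change beyond the scatter is expected, and the estimated step is a 1.1-fold higher number from compound 3 to compound 4 (0.03 log units; within the scatter). Compound 4 is expected to give about 16000 nM, with an estimated range from 8000 nM to 30000 nM.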

Compound 4, half-maximal effective concentration: > 25000 nM
Compound 4: a limit, no number; the forecaster's own chance of this, stated with the estimate: 10%; at least 1.5-fold (0.19 log units) between middle value and limit.
By their numbers in this assay, from the lowest: compounds 3, 1 and 2 (each within the scatter of the next). At a limit, above all of these: compound 4.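

In this assay, among these compounds, compound 4 gives > 25000 nM, which is a limit of the assay and not a number, so chloro is the first group at this place, on an aromatic carbon para to a large group, that yields no middle value. Its steps can therefore be read only as floors: an at least 1.6-fold higher number from compound 3 to compound 4 (0.22 log units; that floor lies within the scatter), an at least 1.2-fold higher number from compound 2 to compound 4 (0.09 log units; that floor lies within the scatter) and an at least 1.4-fold higher number from compound 1 to compound 4 (0.16 log units; that floor lies within the scatter). Trifluoromethoxy, methoxycarbonyl and tert-butyl gave numbers that could not be told apart, but chloro cannot yet be placed level with them or clearly apart from them, and the size of its real step stays unknown because the result is capped: the limit of > 25000 nM in this assay, at which 1 of the 4 values shown sits.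

The compounds shown give no actual number for compound 4, so whether chloro truly differs from the other three groups remains open. Also open, on these data alone, is what a group of another kind at this place, such as an amine, a carboxylic acid or a longer chain, would do in this assay, and whether changes elsewhere on the shared core would matter more than those at this place.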